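Pentyl to tert-butoxycarbonyl on the compound 3 chain

The source may report more compounds than this note shows. Statements on the series, on what has been measured and on what is new or still open speak of the compounds shown alone.

In an ADME assay for permeability, using PAMPA, at pH 4 (on this read-out higher numbers stand for higher permeability and lower numbers for lower permeability), compound 3 (`CCCCC/C=C/c1c(C)[nH]c2cc(OC)c(Cl)cc2c1=O`) gives 280 10^-6 cm/s and stands second highest of three numbers, below compound 2 (`C=C(CCCCC)c1c(C)[nH]c2cc(OC)c(Cl)cc2c1=O`) at 768 10^-6 cm/s. Compound 1 (`COc1cc2[nH]c(C)c(C)c(=O)c2cc1Cl`) gives 37 10^-6 cm/s on the same read-out. Compound 4 (`COc1cc2[nH]c(C)c(/C=C/C(=O)OC(C)(C)C)c(=O)c2cc1Cl`) differs from compound 3 in one place (tert-butoxycarbonyl in place of pentyl on a double-bonded chain carbon bound to a double-bonded chain carbon) with tert-butoxycarbonyl in place of pentyl on a double-bonded chain carbon bound to a double-bonded chain carbon. Among the measured compounds shown here, three measured steps bear on this (a 7.6-fold higher number from compound 1 to compound 3 (0.88 log units; beyond the scatter)) (a 21-fold higher number from compound 1 to compound 2 (1.32 log units; beyond the scatter)) (a 2.7-fold lower number from compound 2 to compound 3 (0.44 log units; beyond the scatter)) but none of them swaps pentyl for tert-butoxycarbonyl. Compound 3 may therefore give back part of its measured rise over compound 1 when pentyl leaves. The expected step in this assay is a 2.5-fold lower number from compound 3 to compound 4 (0.41 log units; beyond the scatter) and it remains loosely founded. For compound 4 the estimate is 110 10^-6 cm/s with an expected range from 30 10^-6 cm/s to 300 10^-6 cm/s on this read-out.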

Compound 4, apparent permeability: 249 10^-6 cm/s
Compound 4: the middle estimate sits 2.3-fold (0.35 log units) below what was measured; measured number inside the range.
By their numbers in this assay, from the lowest: compound 1; then compounds 4 and 3 (each within the scatter of the next); then compound 2.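

In this assay, tert-butoxycarbonyl in place of pentyl on a double-bonded chain carbon bound to a double-bonded chain carbon leaves the number within the scatter (a 1.1-fold lower number from compound 3 to compound 4 (0.05 log units; within the scatter)). The earlier steps shown here involved only all-carbon groups, whereas this pair shows that oxygen atoms and hydrogen-bond acceptors can enter here with no change beyond the scatter. No available evidence bears on this result. From the compounds shown here alone, whether a carboxylic acid or an amine at this place would also stay within the scatter of compound 3 remains open.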